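Chloro in place of methylsulfonyl on the alkyne aryl ring

A few compounds are considered here, and "the series" means these few. Any claim that something is new, unique, unknown or untested is made for them only; others in the source may bear on it.

Of the compounds shown here, three share a core and have been measured in an assay on CHO cells for displacement of a labelled ligand from prostaglandin D2 receptor 2 (Homo sapiens), read by scintillation counting; on this read-out lower numbers stand for stronger inhibition and higher numbers for weaker inhibition. Compound 1 `CS(=O)(=O)c1cccc(C#Cc2cc(Cl)ccc2OCC(=O)O)c1` gives 15 nM. Compound 2 `CS(=O)(=O)c1ccc(C#Cc2cc(Cl)ccc2OCC(=O)O)cc1` gives 86 nM. Compound 3 `COCCNS(=O)(=O)c1ccc(C)c(C#Cc2cc(Cl)ccc2OCC(=O)O)c1` gives 3.6 nM. Compound 2 therefore stands at the highest number of the three: compound 1 lies a good way lower, beyond the scatter, and compound 3 lies furthest below it.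

The next compound, compound 4 `O=C(O)COc1ccc(Cl)cc1C#Cc1ccc(Cl)cc1`, has not yet been measured. It differs from compound 2 in one place: chloro in place of methylsulfonyl on an aromatic carbon. Among the measured compounds shown here, no pair among the measured compounds shows this change, so there is no measured step to lean on; the only guide is where compound 2 stands in this assay with 86 nM.

With nothing in the series to suggest a large shift, compound 4 is expected to give about 150 nM in this assay, within a range of 40 nM to 600 nM. The step of a 1.7-fold higher number from compound 2 to compound 4 (0.24 log units; within the scatter) is thus estimated to be small, toward a higher number, and may well stay within the scatter.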

Compound 4, inhibition constant: 60 nM
The estimate for compound 4 lay 2.5-fold (0.40 log units) above the measured number; the measured number falls inside the stated range.
By their numbers in this assay, from the lowest: compound 3; then compound 1; then compounds 4 and 2 (each within the scatter of the next).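

In this assay, among the compounds shown here, a 1.4-fold lower number from compound 2 to compound 4 (0.16 log units; within the scatter) is the first measured step at this place, on an aromatic carbon para to a large group. Methylsulfonyl, with 4 heavy atoms and 2 hydrogen-bond acceptors, gives way to chloro, with 1 heavy atom and no hydrogen-bond acceptors, and the step stays within the scatter. So for this pair, neither the sulfur and oxygen atoms nor the counted acceptors of methylsulfonyl are needed to hold the number at this level, though no measurement on hand explains the result.

Open, as far as these compounds go, is whether an amine, a carboxylic acid or a longer chain at this place would also stay within the scatter of compound 2. Also open, from the compounds shown here alone, is whether chloro can replace methylsulfonyl as quietly at the place it occupies in compound 1.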